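Working notes on the step from compound 2 to compound 3

A few compounds are considered here, and "the series" means these few. Any claim that something is new, unique, unknown or untested is made for them only; others in the source may bear on it.

Compound 1 `CC(=O)c1cc2ccc(OCCCn3cc(CNC(=O)CCCCC4CCSS4)nn3)cc2oc1=O` and compound 2 `COc1ccc(-c2cc3ccc(OCCCn4cc(CNC(=O)CCCCC5CCSS5)nn4)cc3oc2=O)cc1` have been measured in a functional assay on PC-12 cells (Rattus norvegicus) for cytotoxicity, read by MTT assay, with stated times of 3 h and 2 h, tested at 0.1 uM; on this read-out lower numbers stand for a weaker effect and higher numbers for a stronger effect at the one concentration tested. In this assay compound 1 gives 34.6%, and compound 2 gives 42%. Within the data shown here, the single step between them, a number 7.4 percentage points higher from compound 1 to compound 2 (within the scatter), lies within the scatter, so compound 2 stands at one of two numbers that cannot be told apart. Compound 3 `O=C(CCCCC1CCSS1)NCc1cn(CCCOc2ccc3cc(-c4ccc(Br)cc4)c(=O)oc3c2)nn1` is not yet measured. Its difference from compound 2 is bromo in place of methoxy on an aromatic carbon. Among the measured compounds shown here, no measured step touches this position; the only step seen so far changed another group and stayed within the scatter. With no evidence that a change at this place moves the read-out, compound 3 is expected to sit close to compound 2, and the step of no change at the digits printed from compound 2 to compound 3 (within the scatter) is expected to stay within the scatter. The estimate for compound 3 is 42%, with a range of 28% to 56%.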

Compound 3, a percentage reported as activity, at one concentration (the size of the read-out at that concentration, not a potency): 39.5%
Compound 3: the middle estimate sits 2.5 percentage points above what was measured, within the range that was stated.
By their numbers in this assay, from the lowest: compounds 1, 3 and 2 (each within the scatter of the next).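

In this assay, among these compounds, the first change at this position gives a number 2.5 percentage points lower from compound 2 to compound 3 (within the scatter), so at the one concentration tested, bromo and methoxy on this aromatic carbon cannot be told apart. The step of a number 4.9 percentage points higher from compound 1 to compound 3 (within the scatter) shows that 4-bromophenyl in place of acetyl also stays within the scatter, as 4-methoxyphenyl did, so neither replacement of acetyl nor the change on the outer aromatic ring has yet shifted the read-out measurably. No supporting measurement bears on this result, and the data offer no explanation for it.

On these data alone, it remains open whether an amine or a carboxylic acid at this aromatic carbon would move the read-out beyond the scatter. As far as these compounds go, it also remains open whether these three compounds would separate at any other concentration in this assay.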